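The source may report more compounds than this note shows. Statements on the series, on what has been measured and on what is new or still open speak of the compounds shown alone.

Measured so far:
compound 1, `COc1cc(NC(C)CCCNC(=O)NNC(=O)N(CCO)CCO)c2ncccc2c1`, > 250000 nM
compound 2, `COc1cc(NC(C)CCCNC(=O)NNC(=O)N(C)C(c2ccccc2)c2ccccc2)c2ncccc2c1`, 18000 nM
compound 3, `O=C(NC(c1ccccc1)c1ccc(Cl)cc1)NC(c1ccccc1)c1ccc(Cl)cc1`, 97000 nM

All three compounds were tested in a functional assay on MIA PaCa-2 cells (Homo sapiens) for inhibition, read by MTT assay, with a stated time of 4 days; a higher number here means a weaker inhibitor, a lower number a stronger inhibitor. For compound 1 the result is only a limit, > 250000 nM, and not a measured number. Compound 1 therefore stands at the limit of > 250000 nM in this assay, at which 1 of the 3 values shown sits. Compound 2 gives 18000 nM in this assay, and compound 3 gives 97000 nM; both of these are numbers, and compound 2 is the only one of the three with a clear reading well inside the measurable range.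

Compound 4, `COc1cc(NC(C)CCCNC(=O)NNC(=O)NCCCCCO)c2ncccc2c1`, has not yet been measured. It shares the core of compound 1 and differs from it in a single place: (5-hydroxypentyl)amino in place of bis(2-hydroxyethyl)amino on a carbonyl carbon. For the measured compounds named here, no pair of measured compounds differing in just this way is available, so nothing measured tells how large a step this kind of change brings. Given that compound 1 itself gave only a limit, the expectation for compound 4 is a step of no more than the usual scatter, in no particular direction, and a fair chance that this assay again reports only a limit. The expected step from compound 1 to compound 4 is a number no higher from compound 1 to compound 4 (the limit leaves the size open). Compound 4 is estimated at 250000 nM, with a plausible range from 60000 nM to 1000000 nM.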

Compound 4, half-maximal inhibitory concentration: 168000 nM
Estimate against measurement, compound 4: 1.5-fold (0.17 log units) above, within the range that was stated.
By their numbers in this assay, from the lowest: compound 2; then compounds 3 and 4 (each within the scatter of the next). At a limit, above all of these: compound 1.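

In this assay, compound 4 gives a measured number, 168000 nM, so this position on the carbonyl carbon now has a reading that sits on the scale. From the compounds shown here alone, putting (5-hydroxypentyl)amino in place of bis(2-hydroxyethyl)amino gives an at least 1.4-fold lower number from compound 1 to compound 4 (0.17 log units; that floor lies within the scatter), which means that the true size of the step stays unknown and that even its smallest possible size cannot be told apart from ordinary repeat variation. Only this lower bound can be stated, and it is fixed by compound 1, whose result is a limit and not a number: the limit of > 250000 nM in this assay, at which 1 of the 4 values shown sits.

This single change alters both the branching and the count of hydroxyl groups, so the compounds shown cannot separate the two effects on the reading. Going by these compounds, it also remains open whether a longer chain ending in a hydroxyl group, or a chain of the same length ending in an amine or a carboxylic acid, would give a clearly lower number than compound 4 in this assay.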